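The source may hold more compounds than are shown below. What is called first, only, known or untested is meant among the compounds shown, and "the series" means these compounds.

In a functional assay on SMMC-7721 cells (Homo sapiens) for cytotoxicity, read by MTT assay, with a stated time of 24 h (a higher number here means a weaker inhibitor, a lower number a stronger inhibitor), compound 1 `CN1C/C(=C\c2cccnc2)C(=O)/C(=C/c2ccccc2C(F)(F)F)C1` gives 3900 nM and compound 2 `CN1C/C(=C\c2ccncc2)C(=O)/C(=C/c2ccccc2C(F)(F)F)C1` gives 4100 nM. Among the compounds with values here, the only measured step, a 1.1-fold higher number from compound 1 to compound 2 (0.02 log units; within the scatter), stays within the scatter, so compound 2 stands level with compound 1. Compound 3 `O=C1/C(=C/c2cccnc2)CN(S(=O)(=O)c2ccc([N+](=O)[O-])cc2)C/C1=C\c1ccccc1F` returns only a limit, > 20000 nM.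

The piece now turns to compound 4 `O=C1/C(=C/c2ccncc2)CN(S(=O)(=O)c2ccc(F)cc2)C/C1=C\c1ccccc1C(F)(F)F`, which differs from compound 2 on the amine nitrogen in a ring: (4-fluorophenyl)sulfonyl in place of methyl on an amine nitrogen in a ring. There, (4-fluorophenyl)sulfonyl takes the place of methyl. The measured step concerns the pyridinyl group, not this nitrogen, so it gives no guide to the size of the change. Compound 3 also carries a sulfonyl group on that nitrogen, but it differs from compound 4 in other places as well, so any lean toward a higher number rests only loosely on (the limit of > 20000 nM in this assay, at which 1 of the 3 values shown sits). In this assay, the expected change is a moderate move toward weaker inhibition, estimated as a 1.7-fold higher number from compound 2 to compound 4 (0.23 log units; within the scatter). For compound 4 the estimated value is 7000 nM, with an expected range from 2000 nM to 20000 nM.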

Compound 4, half-maximal inhibitory concentration: 9270 nM
Compound 4: the middle estimate sits 1.3-fold (0.12 log units) below what was measured; low and high end bracket the measured number.
By their numbers in this assay, from the lowest: compounds 1 and 2 (each within the scatter of the next); then compound 4. At a limit, above all of these: compound 3.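

In this assay, within the data shown here, the amine nitrogen in the ring responds to substitution: (4-fluorophenyl)sulfonyl in place of methyl gives a 2.3-fold higher number from compound 2 to compound 4 (0.35 log units; beyond the scatter), a modest step, whereas the only earlier step, at the pyridinyl group, stayed within the scatter. This large replacement for methyl does not abolish the read-out, since compound 4 still gives 9270 nM, a number and not a limit. Nothing measured here accounts for the size of this step.

The compounds shown leave open how an acetyl, benzyl or methanesulfonyl group on this nitrogen would read, and so whether the step follows the sulfonyl link or the 4-fluorophenyl ring. As far as these compounds go, it also remains open whether the same replacement gives a similar step when pyridin-3-yl stands in place of pyridin-4-yl.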